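Chloro effects on the bicyclic amine series

The source may hold more compounds than are shown below. What is called first, only, known or untested is meant among the compounds shown, and "the series" means these compounds.

Compound 1 `c1cncc(N2CC[C@@H]3CN[C@@H]3C2)c1` carries the unsubstituted pyridine and in a functional assay on HEK293 cells for agonist activity at Neuronal acetylcholine receptor; alpha3/beta4 (Homo sapiens), read by FLIPR (on this read-out higher numbers stand for an effect only at larger amounts of compound and lower numbers for an effect already at smaller amounts), compound 1 gives 260 nM. Compound 2 `Clc1ccc(N2CC[C@@H]3CN[C@@H]3C2)cn1` differs from it by chloro in place of hydrogen on an aromatic carbon; in this assay compound 2 gives 25 nM. The step of a 10-fold lower number from compound 1 to compound 2 (1.02 log units; beyond the scatter) is the one measured change of this kind in the set.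

Compound 3 `Clc1ccc(N2C[C@@H]3CCNC[C@@H]32)cn1` is built on a different core; the difference between the two cores is not broken down here. In this assay compound 3 gives 1390 nM, the highest of the three numbers, and compound 2 sits far below it.

Compound 4 `Clc1cc(N2C[C@@H]3CCNC[C@@H]32)cnc1Cl` is not yet measured. It differs from compound 3 by chloro in place of hydrogen on an aromatic carbon. Going by the values given here, the change is the same kind of change as the one from compound 1 to compound 2, but not the same: in the measured case the chloro enters next to the ring nitrogen and para to a group of 8 heavy atoms, whereas here it enters ortho to a chloro group, two atoms from the ring nitrogen and meta to a group of 8 heavy atoms. Compound 3 already holds the chloro that in compound 2 gave the large drop, so the second chloro is expected to bring a smaller step, roughly a 2.5-fold lower number from compound 3 to compound 4 (0.40 log units; beyond the scatter), because the large gain of a 10-fold lower number from compound 1 to compound 2 (1.02 log units; beyond the scatter) is already spent. Compound 4 is therefore estimated at 550 nM, between 150 nM and 2000 nM.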

Compound 4, half-maximal effective concentration: 4110 nM
For compound 4 the middle estimate is 7.5-fold (0.87 log units) below the measured one; the measured number lies above the stated range.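

The second chloro gives a 3.0-fold higher number from compound 3 to compound 4 (0.47 log units; beyond the scatter), so on this core the number moves the opposite way from the earlier step. Set beside that earlier step, chloro in place of hydrogen on an aromatic carbon does not carry over from one core to the other in this assay with either its direction or its size: the same change on two cores in this assay, a 10-fold lower number (1.02 log units; beyond the scatter) from compound 1 to compound 2 and a 3.0-fold higher number (0.47 log units; beyond the scatter) from compound 3 to compound 4, 31-fold (1.49 log units) apart, beyond the scatter of two such steps

This does not show that the core alone sets the outcome: the two steps also differ in where the chloro enters, since in compound 4 it stands ortho to a chloro group, two atoms from the ring nitrogen and meta to a group of 8 heavy atoms, and compound 3 already holds a chloro while compound 1 holds none, so core, place and the chloro already present cannot be told apart from one pair on each core.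

Open, as far as these compounds go, is how the core of compound 1 responds to a second chloro group, and how the core of compound 3 stands with no chloro on its pyridine at all. Also open, from the compounds shown here alone, is whether a methyl, a methoxy or an amine in the place taken by the second chloro of compound 4 would move the number the same way.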